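A few compounds are considered here, and "the series" means these few. Any claim that something is new, unique, unknown or untested is made for them only; others in the source may bear on it.

In a functional assay on HepG2 cells (Homo sapiens) for antiproliferative activity, read by MTT assay, with a stated time of 24 h (on this read-out lower numbers stand for stronger inhibition and higher numbers for weaker inhibition), compound 2 `Clc1ccc(C2CC(c3ccccc3)=NN2c2ccc(-c3ccccc3)nn2)cc1` gives 6310 nM. Its nearest comparison is compound 1 `c1ccc(C2=NN(c3ccc(-c4ccccc4)nn3)C(c3ccccc3)C2)cc1`, which gives 10000 nM in this assay, and the two numbers lie within the usual scatter of each other. Within the data shown here, the one measured step, a 1.6-fold lower number from compound 1 to compound 2 (0.20 log units; within the scatter), came from chloro in place of hydrogen on an aromatic carbon and did not rise above the scatter. Compound 3 `Fc1ccc(C2CC(c3ccccc3)=NN2c2ccc(-c3ccccc3)nn2)cc1` differs from compound 2 by fluoro in place of chloro on an aromatic carbon. Only the hydrogen-to-chloro step bears on this change, and it was small; replacing one halogen by another at the same carbon, after hydrogen and chloro already gave numbers within the scatter, gives no ground to expect a step beyond the scatter in this assay. The step from compound 2 to compound 3 is therefore estimated as a 1.2-fold higher number from compound 2 to compound 3 (0.08 log units; within the scatter), with no preferred direction. Compound 3 is accordingly expected to give about 7500 nM in this assay, within a range from 3500 nM to 16000 nM.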

Compound 3, half-maximal inhibitory concentration: 8420 nM
Beside the measured number, compound 3's estimate is 1.1-fold (0.05 log units) below it; low and high end bracket the measured number.
By their numbers in this assay, from the lowest: compounds 2, 3 and 1 (each within the scatter of the next).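

At this carbon, para to a large group, the exchange of 4-chlorophenyl for 4-fluorophenyl gave a 1.3-fold higher number from compound 2 to compound 3 (0.13 log units; within the scatter) in this assay and so stayed inside the scatter, which the earlier pair, covering only hydrogen and chloro, could not show. Fluoro in place of hydrogen at the same carbon gave a 1.2-fold lower number from compound 1 to compound 3 (0.07 log units; within the scatter) and also stayed inside the scatter, so hydrogen, chloro and fluoro at this position are not told apart by this read-out in the three compounds shown. Nothing at hand ties these numbers to any property of the two halogens or explains them.

From the compounds shown here alone, whether a group of another kind at this carbon, such as an amine, a methoxy group or a carboxylic acid, would give a number beyond the scatter remains open. Also open, going by these compounds, is whether the same halogens placed on the other aromatic rings of the shared core would leave the number just as little moved.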